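Swapping 4-(methoxycarbonyl)phenyl for 2-cyanophenyl on the side chain

The source may hold more compounds than are shown below. What is called first, only, known or untested is meant among the compounds shown, and "the series" means these compounds.

In a functional assay on a cell-free system (plasma, Oryctolagus cuniculus) for inhibition, with stated times of 5 min, 1 min and 6 min (a higher number here means a weaker inhibitor, a lower number a stronger inhibitor), compound 1 (`CCOC(=O)c1c(C)nc(-c2cccc(C#N)c2)n1OCCC(=O)O`) shows > 30000 nM as its reading, which is a limit of the assay and not a number. In this assay compound 2 (`CCOC(=O)c1c(C)nc(-c2cccc(C#N)c2)n1OCc1ccccc1F`) gives 8990 nM and compound 3 (`CCOC(=O)c1c(C)nc(-c2cccc(C#N)c2)n1OCc1ccc(C(=O)OC)cc1`) gives 9470 nM as half-maximal inhibitory concentrations. Compound 3 thus stands level with compound 2, and both stand clear of compound 1. Replacing carboxymethyl gave an at least 3.3-fold lower number from compound 1 to compound 2 (0.52 log units; beyond the scatter) with one aromatic group and an at least 3.1-fold lower number from compound 1 to compound 3 (0.50 log units; beyond the scatter) with the other.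

Compound 4 (`CCOC(=O)c1c(C)nc(-c2cccc(C#N)c2)n1OCc1ccccc1C#N`) carries 2-cyanophenyl in place of 4-(methoxycarbonyl)phenyl on the same chain carbon. The change counts as 2-cyanophenyl in place of 4-(methoxycarbonyl)phenyl on a saturated chain carbon bound to an oxygen on an aromatic ring in full. The closest guide is the exchange of one aromatic group for another between compound 2 and compound 3, which gave a 1.1-fold higher number from compound 2 to compound 3 (0.02 log units; within the scatter) at this place. No step beyond the scatter is therefore expected in this assay here. The expected result is a 1.1-fold lower number from compound 3 to compound 4 (0.02 log units; within the scatter) for this swap. Compound 4 is estimated at 9000 nM with an expected range from 4000 nM to 20000 nM once measured.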

Compound 4, half-maximal inhibitory concentration: 9380 nM
The estimate for compound 4 lay 1.0-fold (0.02 log units) below the measured number, and the stated range covers the measured number.
By their numbers in this assay, from the lowest: compounds 2, 4 and 3 (each within the scatter of the next). At a limit, above all of these: compound 1.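

In this assay a third aromatic group at this place leaves the reading level, with a 1.0-fold lower number from compound 3 to compound 4 (0.00 log units; within the scatter) for the exchange of the whole group and a 1.0-fold higher number from compound 2 to compound 4 (0.02 log units; within the scatter) for cyano in place of fluoro on the ring. Among compounds 2, 3 and 4, the three substituted phenyl groups on this chain carbon thus read alike, despite carrying fluoro, methoxycarbonyl or cyano. The separation from compound 1 also extends to 2-cyanophenyl, with an at least 3.1-fold lower number from compound 1 to compound 4 (0.50 log units; beyond the scatter) as the step, but compound 1 reads at a limit of the assay, so this step gives only a bound: the limit of > 30000 nM in this assay, at which 1 of the 4 values shown sits.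

The compounds shown leave open whether any group on this chain carbon can bring the number well below these three. From the compounds shown here alone, how an amine on the ring, or a saturated ring in place of the phenyl, would read also remains unknown.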